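Swapping a Five-Membered Amine Ring for a Six-Membered One

The source may hold more compounds than are shown below. What is called first, only, known or untested is meant among the compounds shown, and "the series" means these compounds.

Of the compounds shown here, two have been tested in a functional assay on PC-3 cells (Homo sapiens) for antiproliferative activity, read by MTT assay, with a stated time of 72 h; a lower number here means a stronger inhibitor, a higher number a weaker inhibitor. Compound 2 `COc1cc2ncnc(N3CCCc4ccccc43)c2cc1NC(=O)/C=C/CN1CCCC1` gives 1740 nM, the lower of the two numbers. Compound 1 `COc1cc2ncnc(N3CCc4ccccc43)c2cc1NC(=O)/C=C/CN1CCCCC1` gives 4180 nM, a gap beyond the usual scatter. Compound 3 `COc1cc2ncnc(N3CCCc4ccccc43)c2cc1NC(=O)/C=C/CN1CCCCC1` has not yet been measured; it differs from compound 2 by piperidin-1-yl in place of pyrrolidin-1-yl on a saturated chain carbon bound to a double-bonded chain carbon. For the measured compounds named here, no measured pair shows this change on its own, so there is no step to lean on. Such a swap is expected to shift this assay by no more than the scatter, perhaps slightly toward a weaker compound. Compound 3 is therefore estimated at 2200 nM, within 900 nM to 5500 nM. That corresponds to an expected step of a 1.3-fold higher number from compound 2 to compound 3 (0.10 log units; within the scatter).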

Compound 3, half-maximal inhibitory concentration: 5780 nM
Compound 3: the middle estimate sits 2.6-fold (0.42 log units) below what was measured; measured number above the stated range.
By their numbers in this assay, from the lowest: compound 2; then compounds 1 and 3 (each within the scatter of the next).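

In this assay, piperidin-1-yl in place of pyrrolidin-1-yl on a saturated chain carbon bound to a double-bonded chain carbon gives a 3.3-fold higher number from compound 2 to compound 3 (0.52 log units; beyond the scatter), so this position distinguishes the two amine rings. With piperidin-1-yl held fixed, 1,2,3,4-tetrahydroquinolin-1-yl and 2,3-dihydro-1H-indol-1-yl on an aromatic carbon cannot be told apart, at a 1.4-fold higher number from compound 1 to compound 3 (0.14 log units; within the scatter) and no more. Nothing measured here gives a reason for the step at the chain.

As far as these compounds go, whether an open-chain amine such as dimethylamino, or morpholine, would sit nearer compound 2 or compound 3 remains open. So does whether pyrrolidin-1-yl keeps its edge alongside 2,3-dihydro-1H-indol-1-yl.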